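Replacing the amino end of compound 3

A few compounds are considered here, and "the series" means these few. Any claim that something is new, unique, unknown or untested is made for them only; others in the source may bear on it.

Measured in a functional assay (trachea) with Cavia porcellus as the target; on this read-out lower numbers stand for stronger inhibition and higher numbers for weaker inhibition:
- Compound 1 `O=c1c2ccccc2c(-c2cccnc2)nn1Cc1ccccc1`: 2450 nM
- Compound 2 `O=c1c2ccccc2c(-c2cccnc2)nn1CCSc1ccccc1`: 9120 nM
- Compound 3 `NCCn1nc(-c2cccnc2)c2ccccc2c1=O`: > 100000 nM

Compound 3 gives only a limit of the assay, not a number. Compound 4 `CC(C)NC(=O)CCCn1nc(-c2cccnc2)c2ccccc2c1=O` keeps the shared core, but (isopropylcarbamoyl)methyl takes the place of amino on a saturated chain carbon, two bonds along the chain from an aromatic nitrogen ((isopropylcarbamoyl)methyl in place of amino on a saturated chain carbon, two bonds along the chain from an aromatic nitrogen). Among the compounds with values here, two measured steps bear on this change, both large: an at least 40-fold higher number from compound 1 to compound 3 (1.61 log units; beyond the scatter) and an at least 10-fold higher number from compound 2 to compound 3 (1.04 log units; beyond the scatter). Read in reverse, they show that the two compounds without the amino end have much lower numbers. The smaller 3.7-fold higher number from compound 1 to compound 2 (0.57 log units; beyond the scatter) shows that the end group still matters. In this assay a large move towards a lower number is therefore expected, an at least 6.6-fold lower number from compound 3 to compound 4 (0.82 log units; beyond the scatter). For compound 4 the estimated value is 15000 nM, with an expected range from 4000 nM to 60000 nM.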

Compound 4, half-maximal inhibitory concentration: 64600 nM
Beside the measured number, compound 4's estimate is 4.3-fold (0.63 log units) below it; the whole stated range lies below it.
By their numbers in this assay, from the lowest: compound 1; then compound 2; then compound 4. At a limit, above all of these: compound 3.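

In this assay the (isopropylcarbamoyl)methyl end gives a countable value at this position, so the chain tolerates an amide end better than the amino end can be shown to, though only as far as a measured number goes. It still gives higher numbers than the ends that carry a benzene ring. Against the phenylsulfanyl end the rise is modest: a 7.1-fold higher number from compound 2 to compound 4 (0.85 log units; beyond the scatter). Against the phenyl end it is large: a 26-fold higher number from compound 1 to compound 4 (1.42 log units; beyond the scatter). The move from the amino end can be given only as a floor: an at least 1.5-fold lower number from compound 3 to compound 4 (0.18 log units; that floor lies within the scatter). It cannot be read as a size, because compound 3 stands at a limit of the assay: the limit of > 100000 nM in this assay, at which 1 of the 4 values shown sits.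

Going by these compounds, whether a carboxylic acid or a dimethylamino group on this chain would behave like the amide remains open. So does whether a phenyl group on the amide nitrogen would recover the lower numbers.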